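Tolerated concentrations of two diynyl nucleosides and a third

This account rests on a few compounds, and the source may have more. Where it says the series, first, only, none or still open, it means among the compounds named here.

Compound 1 `O=c1[nH]c(=O)n([C@H]2C[C@H](O)[C@@H](CO)O2)cc1C#CC#Cc1ccccc1`: 100000 nM
Compound 2 `O=c1[nH]c(=O)n([C@H]2C[C@H](O)[C@@H](CO)O2)cc1C#CC#Cc1ccc([N+](=O)[O-])cc1`: 100000 nM

The two measured compounds share one core and differ only at the far end of the diyne arm. In an ADME assay on HEL cells (Homo sapiens) for cytotoxicity, read by microscopy (a higher number here means that more compound is tolerated, a lower number that less compound is tolerated), compound 1 gives 100000 nM and compound 2 gives 100000 nM. Going by the values given here, the step of no change at the digits printed from compound 1 to compound 2 (within the scatter) is the only comparison in hand, and it shows that placing a nitro in place of hydrogen on an aromatic carbon leaves the tolerated concentration where it was, within the scatter. Compound 1 therefore stands level with compound 2 on the numbers shown, with no other neighbour to set it against.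

Compound 3 `O=c1[nH]c(=O)n([C@H]2C[C@H](O)[C@@H](CO)O2)cc1C#CC#Cc1ccc(OC(F)(F)F)cc1` is not yet measured. It differs from compound 1 by trifluoromethoxy in place of hydrogen on an aromatic carbon. Among the compounds with values here, the one measured step that bears on this, no change at the digits printed from compound 1 to compound 2 (within the scatter), changed the same aromatic position by a different group and moved nothing beyond the scatter. On that single precedent, a step of no change at the digits printed from compound 1 to compound 3 (within the scatter) is expected, that is, none beyond the scatter. Compound 3 is therefore estimated at 100000 nM in this assay, with a range from 40000 nM to 200000 nM.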

Compound 3, minimum cytotoxic concentration: 100000 nM
Beside the measured number, compound 3's estimate shows no gap at the digits printed; the measured number falls inside the stated range.
By their numbers in this assay, from the lowest: compounds 1, 2 and 3 (each within the scatter of the next).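

In this assay, trifluoromethoxy, with its 5 heavy atoms and no ring, enters on an aromatic carbon of a six-membered aromatic ring of carbon only and gives no change at the digits printed from compound 1 to compound 3 (within the scatter). A second group at this position therefore joins nitro in leaving the tolerated concentration where it stood with hydrogen, so the earlier result no longer rests on a single substituent. The new compound also allows the first direct exchange of one group for another at this position, and that exchange gives no change at the digits printed from compound 2 to compound 3 (within the scatter); nothing shown gives a reason for this lack of change.

On these data alone, whether an amine, a carboxylic acid or a longer alkyl chain at the same position would also leave the tolerated concentration unchanged remains open. So does the effect of altering the diyne arm or the shared core, since all three compounds carry both unchanged.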